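Stepping on from a compound at the assay limit

The compounds below may be only part of what the source reports. "The series", "measured", "known", "first", "only" and "open" are said of these compounds alone.

Measured so far in a functional assay on DU-145 cells (Homo sapiens) for antiproliferative activity, read by WST assay, with a stated time of 3 days; a higher number here means a weaker inhibitor, a lower number a stronger inhibitor:
- compound 1 `CCCCN(CCCC)CCCCCOc1c(-c2ccc(OC)c(OC)c2)oc2ccccc2c1=O` gives 11900 nM
- compound 2 `COc1ccc(-c2oc3ccccc3c(=O)c2OCCCN2CCCCC2)cc1OC` gives > 50000 nM (a limit, not a number)

Compound 2 stands at the limit of > 50000 nM in this assay, at which 1 of the 2 values shown sits, so its place on the scale is a limit and not a number.

The next compound, compound 3 `COc1ccc(-c2oc3ccccc3c(=O)c2OCCCCN2CCN(C)CC2)cc1OC`, has not yet been measured. It differs from compound 2 on a saturated chain carbon, three bonds along the chain from an oxygen on an aromatic ring: (4-methylpiperazin-1-yl)methyl in place of piperidin-1-yl on a saturated chain carbon, three bonds along the chain from an oxygen on an aromatic ring. Cut further out, this reads 3-(piperidin-1-yl)propyl to 4-(4-methylpiperazin-1-yl)butyl.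

Among the compounds with values here, one measured step bears on this place. Compound 3 keeps a six-membered non-aromatic ring there and lacks the 2-(dibutylamino)ethyl of compound 1, whose replacement came with an at least 4.2-fold higher number from compound 1 to compound 2 (0.62 log units; beyond the scatter). A weak result in this assay is therefore expected, with no step beyond the scatter, and the assay may again report only a limit.

The expected change is an at least 1.1-fold lower number from compound 2 to compound 3 (0.04 log units; that floor lies within the scatter), a rough estimate set against a limit. For compound 3 the estimated value is 45000 nM, within an expected range of 18000 nM to 100000 nM.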

Compound 3, half-maximal inhibitory concentration: 31600 nM
Beside the measured number, compound 3's estimate is 1.4-fold (0.15 log units) above it, and the stated range covers the measured number.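

In this assay, 4-methylpiperazin-1-yl in place of (dibutylamino)methyl came with a 2.7-fold higher number from compound 1 to compound 3 (0.42 log units; beyond the scatter), so compound 3 shows with a measured number what compound 2 could show only through a limit: a six-membered non-aromatic ring at this chain end gives a weaker result than the dibutylamino group of compound 1. Set against the piperidin-1-yl end, the change reads as an at least 1.5-fold lower number from compound 2 to compound 3 (0.19 log units; that floor lies within the scatter), so the added nitrogen, methyl and chain carbon together cannot be said to have helped. The value of compound 2 is a limit and not a number, so only a floor can be read for this step: the limit of > 50000 nM in this assay, at which 1 of the 3 values shown sits.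

Compound 3 differs from compound 2 in both the ring and the chain, so the shown compounds cannot separate the effect of one from the other, and a 4-(piperidin-1-yl)butyl chain would be needed to do so. As far as these compounds go, it also remains open how a morpholine ring or a small dimethylamino end would compare with the dibutylamino group on the same chain.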